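Aryl swap on the shared core: compound 3 to compound 4

The source may hold more compounds than are shown below. What is called first, only, known or untested is meant among the compounds shown, and "the series" means these compounds.

compound 1 `CCc1cccc(Nc2cc(NC(=O)Nc3cc(OC)cc(OC)c3)ncn2)c1` — 36.7%
compound 2 `COc1cc(NC(=O)Nc2cc(Nc3cccc(C(C)(C)C)c3)ncn2)cc(OC)c1` — 40%
compound 3 `COc1cc(NC(=O)Nc2cc(Nc3ccc(Br)cc3OC)ncn2)cc(OC)c1` — 25.7%
compound 4 `COc1cc(NC(=O)Nc2cc(Nc3cc(F)ccc3OC)ncn2)cc(OC)c1` — not yet measured

In a functional assay on NCI-H226 cells (Homo sapiens) for inhibition, read by MTT assay, with a stated time of 48 h, tested at 10 uM (on this read-out higher numbers stand for more inhibition at the one concentration tested (going by the name of the read-out) and lower numbers for less inhibition), compound 3 gives 25.7% and stands lowest of the three numbers. Both measured steps that reach it lie beyond the scatter and are modest: a number 11 percentage points lower from compound 1 to compound 3 (beyond the scatter) and a number 14.3 percentage points lower from compound 2 to compound 3 (beyond the scatter). The third step, a number 3.3 percentage points higher from compound 1 to compound 2 (within the scatter), lies within the scatter, so the alkyl change on that ring shows no effect that can be read.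

Compound 4 differs from compound 3 in one place: 5-fluoro-2-methoxyphenyl in place of 4-bromo-2-methoxyphenyl on a nitrogen on an aromatic ring. For the measured compounds named here, no measured step bears directly on this change. Going by the values given here, the two steps into compound 3 exchange the whole aryl group on that nitrogen, not one halogen for another within the 2-methoxyphenyl ring, and the one step that keeps the ring and alters a substituent on it stays within the scatter. There is thus no basis in the numbers for a directed step, and the expectation for compound 4 is a change no larger than the scatter, a number 1.3 percentage points higher from compound 3 to compound 4 (within the scatter), with wide uncertainty.

Compound 4 is therefore estimated at 27% in this assay, with a range from 12% to 42%.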

Compound 4, a percentage reported as inhibition, at one concentration (the size of the read-out at that concentration, not a potency): 37.7%
Estimate against measurement, compound 4: 10.7 percentage points below; measured number inside the range.
By their numbers in this assay, from the lowest: compound 3; then compounds 1, 4 and 2 (each within the scatter of the next).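

In this assay, 5-fluoro-2-methoxyphenyl in place of 4-bromo-2-methoxyphenyl on the nitrogen gives a step that can be read, a number 12 percentage points higher from compound 3 to compound 4 (beyond the scatter), so a substituent change that keeps the 2-methoxyphenyl ring can move this read-out, which the alkyl change on the other ring did not show. The low number of compound 3 therefore does not follow from the 2-methoxyphenyl ring alone, and the aryl exchanges tell a different story once the fluoro ring enters: a number 2.3 percentage points lower from compound 2 to compound 4 (within the scatter) and a number 1 percentage points higher from compound 1 to compound 4 (within the scatter), so neither exchange separates the 5-fluoro-2-methoxyphenyl group from the two alkyl-bearing phenyl groups on this measure. Nothing available explains the step from the bromo ring to the fluoro ring.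

The step changes both the halogen and the place it occupies, so the two contributions stay tied together; 4-fluoro-2-methoxyphenyl and 5-bromo-2-methoxyphenyl would separate them. Also open, going by these compounds, is whether a different kind of group on this ring, such as a dimethylamino group or a carboxylic acid, would lower or keep the number of compound 4, 37.7%.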